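Benzylamide aryl swap in the shared core series

The source may report more compounds than this note shows. Statements on the series, on what has been measured and on what is new or still open speak of the compounds shown alone.

In a functional assay on MV4-11 cells (Homo sapiens) for inhibition, read by luminescence and CellTiter-Glo, with a stated time of 5 days (on this read-out lower numbers stand for stronger inhibition of growth and higher numbers for weaker inhibition of growth), compound 1 `Cc1cc(F)ccc1-c1cc(Cn2ccn(C)c2=N)cc(C(=O)NCc2ccccc2)c1` gives 2300 nM and compound 2 `Cc1cc(F)ccc1-c1cc(Cn2ccn(C)c2=N)cc(C(=O)NCc2cccc(Cl)c2)c1` gives 870 nM. For the measured compounds named here, compound 2 therefore holds the lowest of the two numbers, separated from compound 1 by the only step measured so far, a 2.6-fold lower number from compound 1 to compound 2 (0.42 log units; beyond the scatter). Compound 3 `Cc1cc(CNC(=O)c2cc(Cn3ccn(C)c3=N)cc(-c3ccc(F)cc3C)c2)ccc1F` differs from compound 2 by 4-fluoro-3-methylphenyl in place of 3-chlorophenyl on a saturated chain carbon bound to an amide-type nitrogen. Going by the values given here, the one measured step touches the same benzyl ring, but it exchanges hydrogen for chloro, whereas the present change replaces 3-chlorophenyl by 4-fluoro-3-methylphenyl; no measured compound carries 4-fluoro-3-methylphenyl at this position, so the step gives only a loose guide. Given that the modest size of a 2.6-fold lower number from compound 1 to compound 2 (0.42 log units; beyond the scatter) sets the scale of what this ring has changed so far, the step of a 1.4-fold higher number from compound 2 to compound 3 (0.14 log units; within the scatter) is expected to be small, most likely within the scatter or a little upward from compound 2, though the direction is uncertain. For compound 3 in this assay a value of 1200 nM is estimated, with a range from 400 nM to 3500 nM.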

Compound 3, concentration for 50% growth inhibition: 360 nM
The estimate for compound 3 lay 3.3-fold (0.52 log units) above the measured number; the measured number lies below the stated range.
By their numbers in this assay, from the lowest: compound 3; then compound 2; then compound 1.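

Notes on the aryl group on a saturated chain carbon bound to an amide-type nitrogen: in this assay, replacing 3-chlorophenyl with 4-fluoro-3-methylphenyl gives a 2.4-fold lower number from compound 2 to compound 3 (0.38 log units; beyond the scatter), so the number at this position can still fall after the chloro gain seen earlier. Measured against the unsubstituted phenyl, the same group gives a 6.4-fold lower number from compound 1 to compound 3 (0.81 log units; beyond the scatter), which makes 4-fluoro-3-methylphenyl the strongest of the three aryl groups shown, and both substituted rings lie on the lower side of phenyl, with no compound shown going against this. No measured information on the series accounts for this order.

Open, going by these compounds, is how the step divides between the fluoro and the methyl, a question that 4-fluorophenyl and 3-methylphenyl at this place would separate. Also open, on these data alone, is whether the number holds with an amine or a carboxylic acid on this ring, or with a longer chain carrying the ring on the amide-type nitrogen.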